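Extending a Methyl Group by One Carbon

The source may hold more compounds than are shown below. What is called first, only, known or untested is meant among the compounds shown, and "the series" means these compounds.

Three compounds share one core. Compound 1 `O=C(Nc1nn[nH]n1)c1cc(Cl)cc(-c2ccccc2)n1` gives 40% in a functional assay on the whole organism with Rattus norvegicus as the target, at a dose of 1 mg/kg by the oral route; a higher number here means a stronger effect of the compound at the dose given, a lower number a weaker effect. Compound 2 `COc1ccc(-c2cc(Cl)cc(C(=O)Nc3nn[nH]n3)n2)cc1` gives 43%, and compound 3 `Cc1ccc(-c2cc(Cl)cc(C(=O)Nc3nn[nH]n3)n2)cc1` gives 86%, the highest of the three: a number 43 percentage points higher from compound 2 to compound 3 (beyond the scatter) and a number 46 percentage points higher from compound 1 to compound 3 (beyond the scatter). Compound 4 `CCc1ccc(-c2cc(Cl)cc(C(=O)Nc3nn[nH]n3)n2)cc1` differs from compound 3 by methyl in place of hydrogen on a saturated chain carbon bound to an aromatic carbon. Among the compounds with values here, no measured step lengthens a chain; the measured steps only exchange groups on an aromatic carbon, where a number 3 percentage points higher from compound 1 to compound 2 (within the scatter) but a methyl gave a large rise. The change to compound 4 is smaller in kind, so the number is expected to stay near compound 3, and a number 16 percentage points lower from compound 3 to compound 4 (beyond the scatter) is estimated as a modest fall. Compound 4 is therefore expected to give 70%, within 40% to 95%.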

Compound 4, a percentage reported as inhibition, in the whole organism at one dose (the size of the read-out at that dose, not a potency): 49%
Beside the measured number, compound 4's estimate is 21 percentage points above it; the measured number falls inside the stated range.
By their numbers in this assay, from the lowest: compounds 1, 2 and 4 (each within the scatter of the next); then compound 3.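

One added carbon on the methyl group is enough to undo most of its benefit: there is a number 37 percentage points lower from compound 3 to compound 4 (beyond the scatter) in this assay, so this position responds sharply to a very small change. There is also a number 6 percentage points higher from compound 2 to compound 4 (within the scatter) and a number 9 percentage points higher from compound 1 to compound 4 (within the scatter), so the large rise seen with methyl does not extend to ethyl. No measurement here explains this fall. As far as these compounds go, it remains open how a longer chain such as propyl, or a branched group such as isopropyl, would behave on this aromatic carbon. From the compounds shown here alone, an amine or a fluorine there is equally open.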